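The source may report more compounds than this note shows. Statements on the series, on what has been measured and on what is new or still open speak of the compounds shown alone.

Working notes on the series. For the measured compounds named here, in a functional assay on M21 cells (Homo sapiens) for antiproliferative activity, read by sulforhodamine B assay, with a stated time of 48 h (a higher number here means a weaker inhibitor, a lower number a stronger inhibitor), compound 3 (`CCN1CCN(c2ccc(S(=O)(=O)Oc3ccc(OC)c(OC)c3)cc2)C1=O`) gives 35000 nM and is the only compound so far with a true number. Compound 1 (`COc1ccc(OS(=O)(=O)c2ccc(N3CCN(C)C3=O)cc2)cc1`) reads > 100000 nM and this is a limit of the assay. Compound 2 (`CCN1CCN(c2ccc(S(=O)(=O)Oc3ccccc3OC)cc2)C1=O`) reads > 100000 nM and this too is a limit.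

The next entry is compound 4 (`CCN1CCN(c2ccc(S(=O)(=O)Oc3ccc(OC)cc3)cc2)C1=O`). Going from compound 3 to compound 4 puts hydrogen in place of methoxy on an aromatic carbon, ortho to a methoxy group and meta to a large group (hydrogen in place of methoxy on an aromatic carbon). Going by the values given here, no measured pair isolates this change, so the expectation is tentative. Among the measured compounds, the methoxy that leaves occurs only on compound 3 (35000 nM) and that is the one numeric reading. The expected step is a 2.6-fold higher number from compound 3 to compound 4 (0.41 log units; beyond the scatter) in this assay towards weaker inhibition and beyond the usual scatter, with a good chance of a reading at the limit only. For compound 4 the estimated value is 90000 nM with an expected range of 35000 nM to 200000 nM as a working figure.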

Compound 4, half-maximal inhibitory concentration: 26000 nM
For compound 4 the middle estimate is 3.5-fold (0.54 log units) above the measured one, outside the stated range (below it).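

In this assay, hydrogen in place of methoxy on an aromatic carbon, ortho to a methoxy group and meta to a large group, gives a 1.3-fold lower number from compound 3 to compound 4 (0.13 log units; within the scatter), so the readings of the two compounds cannot be told apart and this methoxy is not needed for the activity seen here. The other two changes do register: 4-methoxyphenyl in place of 2-methoxyphenyl on an oxygen gives an at least 3.8-fold lower number from compound 2 to compound 4 (0.58 log units; beyond the scatter), and methyl in place of hydrogen on a saturated chain carbon bound to an amide-type nitrogen in a ring gives an at least 3.8-fold lower number from compound 1 to compound 4 (0.58 log units; beyond the scatter). Both of these steps start from a limit of the assay, so their full size stays open: the limit of > 100000 nM in this assay, at which 2 of the 4 values shown sit.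

As far as these compounds go, whether an amine or a carboxylic acid on the aromatic carbon that lost the methoxy would shift the reading remains open. So does the effect of a longer chain on the ring nitrogen.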